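The compounds below may be only part of what the source reports. "The series", "measured", "known", "first", "only" and "open" are said of these compounds alone.

Measured compounds:
compound 1 `COc1ccc(-c2nc(SCC(=O)c3sc(-c4ccc(Cl)cc4)nc3C)[nH]c(=O)c2C#N)cc1OC` — an ADME assay on HEK293 cells (Homo sapiens) for cytotoxicity, read by MTT assay, with a stated time of 48 h; a higher number here means a weaker inhibitor, a lower number a stronger inhibitor: "not determined" (no result reported)
compound 2 `Cc1nc(-c2ccc(Cl)cc2)sc1C(=O)CSc1nc(-c2ccccc2)c(C#N)c(=O)[nH]1` — this assay: "not determined" (no result reported)
compound 3 `COc1cccc(-c2nc(SCC(=O)c3sc(-c4ccc(Cl)cc4)nc3C)[nH]c(=O)c2C#N)c1` — this assay: 77900 nM

Within the data shown here, three compounds were carried into this assay, but for compound 1 and compound 2 no number was reported, so compound 3 holds the only value in the set: in this assay compound 3 gives 77900 nM, and with no second number there is nothing to set it against. Compound 4 `Cc1nc(-c2ccc(Cl)cc2)sc1C(=O)CSc1nc(-c2ccc(Cl)cc2)c(C#N)c(=O)[nH]1` has not yet been measured. It differs from compound 3 in one place: 4-chlorophenyl in place of 3-methoxyphenyl on an aromatic carbon. Among the measured compounds shown here, no step between two measured compounds is available, so the effect of this exchange cannot be read from a neighbouring pair. For the measured compounds named here, without such an anchor, compound 4 is expected to stay close to compound 3, with a modest drift toward a lower number as the most likely outcome and no step clearly beyond the usual scatter. The step is expected to be a 1.3-fold lower number from compound 3 to compound 4 (0.11 log units; within the scatter). The estimate for compound 4 in this assay is 60000 nM, with a range from 25000 nM to 150000 nM.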

Compound 4, half-maximal inhibitory concentration: 75100 nM
The estimate for compound 4 lay 1.3-fold (0.10 log units) below the measured number; the range from low to high includes it.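

In this assay, among these compounds, putting 4-chlorophenyl in place of 3-methoxyphenyl, on the aromatic carbon ortho to a cyano group, gives a 1.0-fold lower number from compound 3 to compound 4 (0.02 log units; within the scatter), the first step that can be read in this set. For this one pair, the position accepts a different substituent at a different place on the phenyl ring, and the loss of the hydrogen-bond acceptor counted on the leaving group, without the number moving beyond the scatter. No measurement at hand bears on why the two compounds read alike.

On these data alone, whether this holds for a phenyl ring carrying an amine or a carboxylic acid at this position remains open. So does whether a longer chain in place of the phenyl ring would leave the number where it stands.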